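An Ethoxy Group on Two Related Cores, Measured and Expected

The source may report more compounds than this note shows. Statements on the series, on what has been measured and on what is new or still open speak of the compounds shown alone.

Three compounds have been measured in a functional assay on A549 cells (Homo sapiens) for cytotoxicity, read by MTT assay, with a stated time of 72 h; a higher number here means a weaker inhibitor, a lower number a stronger inhibitor:

Compound 1 `Cc1ccc(S(=O)(=O)Nc2cccc3[nH]nc(Br)c23)cc1` gives 82400 nM.
Compound 2 `CCOc1ccc(NS(=O)(=O)c2ccc(C)cc2)c2c(Br)n[nH]c12` gives 17500 nM.
Compound 3 `C=CCn1cc2ccc(NS(=O)(=O)c3ccc(C)cc3)cc2n1` gives 11900 nM.

Compound 2 differs from compound 1 by ethoxy in place of hydrogen on an aromatic carbon and that change produced a 4.7-fold lower number from compound 1 to compound 2 (0.67 log units; beyond the scatter). Compound 3 is built on another core; the difference between the cores of compound 1 and compound 3 is not broken down here. Compound 3 and compound 2 lie within the usual scatter of each other, while compound 3 stands beyond the scatter from compound 1.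

Compound 4 `C=CCn1cc2ccc(NS(=O)(=O)c3ccc(C)cc3)c(OCC)c2n1` is not yet measured and differs from compound 3 by ethoxy in place of hydrogen on an aromatic carbon. This is the same kind of change as that from compound 1 to compound 2, though not the same: in compound 2 the group sits para to a large group, in compound 4 ortho to a large group. The expectation rests on compound 2, with its a 4.7-fold lower number from compound 1 to compound 2 (0.67 log units; beyond the scatter), tempered by the changed surroundings. Compound 4 is therefore expected to show a 2.6-fold lower number from compound 3 to compound 4 (0.42 log units; beyond the scatter) in this assay. Compound 4 is estimated at 4500 nM, with a range from 1500 nM to 13000 nM.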

Compound 4, half-maximal inhibitory concentration: > 100000 nM
Compound 4 gave a limit, no number; the forecaster's own chance of this, stated with the estimate: 3%; at least 22-fold (1.34 log units) between middle value and limit.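

Compound 4 gives > 100000 nM in this assay, which is a limit of the assay and not a number: the limit of > 100000 nM in this assay, at which 1 of the 4 values shown sits.

Ethoxy in place of hydrogen on an aromatic carbon gave an at least 8.4-fold higher number from compound 3 to compound 4 (0.92 log units; beyond the scatter), so the change did not carry from one core to the other, and its direction reversed: the same change on two cores in this assay, a 4.7-fold lower number (0.67 log units; beyond the scatter) from compound 1 to compound 2 and an at least 8.4-fold higher number (0.92 log units; beyond the scatter) from compound 3 to compound 4, at least 39-fold (1.59 log units) apart, beyond the scatter of two such steps

This rests on a single pair for each core, and the two pairs differ both in the core and in where the ethoxy sits, so it does not show which of these accounts for the reversal. The compounds shown leave open whether a methoxy or a hydroxyl group in the same place on the core of compound 3 would behave as the ethoxy does in compound 4.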